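A second hydroxy on a compound at the limit

The compounds below may be only part of what the source reports. "The series", "measured", "known", "first", "only" and "open" are said of these compounds alone.

Compound 1 `Cn1c(/C=C/C(=O)c2ccccc2O)cc(Br)c1Br` gives 1250 nM
Compound 2 `Cn1c(/C=C/C(=O)c2ccccc2)cc(Br)c1Br` gives >= 100000 nM (a limit)
Compound 3 `Cn1c(/C=C/C(=O)c2cccc(O)c2)cc(Br)c1Br` gives >= 100000 nM (a limit)

All three results come from a functional assay on PA-1 cells (Homo sapiens) for cytotoxicity, read by MTT assay, with stated times of 6 h and 48 h; on this read-out higher numbers stand for weaker inhibition and lower numbers for stronger inhibition. Compound 3 has no exact number and stands at the limit of >= 100000 nM in this assay, at which 2 of the 3 values shown sit. Compound 4 `Cn1c(/C=C/C(=O)c2cc(O)ccc2O)cc(Br)c1Br` differs from compound 3 in one place: hydroxy in place of hydrogen on an aromatic carbon. The new hydroxy is ortho to a large group, and compound 1 carries a hydroxy ortho to the same group.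

Going by the values given here, two measured steps bear on this change. Replacing the hydroxy of compound 1 with hydrogen gave an at least 80-fold higher number from compound 1 to compound 2 (1.90 log units; beyond the scatter), a large step. The other, a step that the two limits leave unreadable from compound 2 to compound 3, cannot be read, so it gives no size to work from. Compound 4 regains the hydroxy of compound 1, which gives 1250 nM, so a large drop toward lower numbers is expected in this assay. Among the compounds with values here, the second hydroxy of compound 4 has no measured precedent, so the range stays wide. The expected change is an at least 40-fold lower number from compound 3 to compound 4 (1.60 log units; beyond the scatter). For compound 4 the estimated value is 2500 nM, with an expected range of 400 nM to 30000 nM.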

Compound 4, half-maximal inhibitory concentration: 380 nM
Beside the measured number, compound 4's estimate is 6.6-fold (0.82 log units) above it; measured number outside the range, below it.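

In this assay, a hydroxy ortho to a large group gives an at least 260-fold lower number from compound 3 to compound 4 (2.42 log units; beyond the scatter), so this position still counts when a second hydroxy sits on the same ring. The size of the change on the two cores can only be compared loosely: the same change on two cores in this assay, an at least 80-fold higher number (1.90 log units; beyond the scatter) from compound 1 to compound 2 and an at least 260-fold higher number (2.42 log units; beyond the scatter) from compound 4 to compound 3; the limit leaves it open whether they differ The hydroxy para to it also counts once the first is in place, with a 3.3-fold lower number from compound 1 to compound 4 (0.52 log units; beyond the scatter), a modest step but one beyond the scatter.

From the compounds shown here alone, compound 2 and compound 3 both stand at a limit, so the step between them cannot be read, and what the second hydroxy does without the first stays unknown: the limit of >= 100000 nM in this assay, at which 2 of the 4 values shown sit. Whether an amine or a methoxy group ortho to the large group would act like the hydroxy also remains open.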